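Series of triazole cage compounds: step to compound 4

The compounds below may be only part of what the source reports. "The series", "measured", "known", "first", "only" and "open" are said of these compounds alone.

Measured so far:
Compound 1, `CCSCCC12CCC(c3nnc(-c4ccccc4C(F)(F)F)n3C)(CC1)CC2` — 72%
Compound 2, `Cn1c(-c2ccccc2C(F)(F)F)nnc1C12CCC(CCS(C)(=O)=O)(CC1)CC2` — 63%
Compound 3, `CCS(=O)(=O)CCCCC12CCC(c3nnc(-c4ccccc4C(F)(F)F)n3C)(CC1)CC2` — 58%

In a functional assay on the whole organism (strain ICR) for inhibition, with Mus musculus as the target, with a stated time of 16 h, at a dose of 10 mg/kg by the oral route (on this read-out lower numbers stand for less inhibition and higher numbers for more inhibition at the one dose given (going by the name of the read-out)), compound 3 gives the lowest of the three numbers. Its nearest neighbour is compound 2; that pair is within the scatter, so no order is drawn between them. Among the measured compounds shown here, the one step beyond the scatter is a number 14 percentage points lower from compound 1 to compound 3 (beyond the scatter), while a number 9 percentage points lower from compound 1 to compound 2 (within the scatter) and a number 5 percentage points lower from compound 2 to compound 3 (within the scatter) are both within the scatter.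

Compound 4, `CC(F)CCCC12CCC(c3nnc(-c4ccccc4C(F)(F)F)n3C)(CC1)CC2`, differs from compound 3 at one place: 1-fluoroethyl in place of (ethylsulfonyl)methyl on a saturated chain carbon, three bonds along the chain from a saturated ring carbon. What leaves carries the two hydrogen-bond acceptors and what enters carries none.

The step from compound 1 to compound 3 bears most on this change, since compound 1 carries the ethylsulfanyl chain without the sulfonyl group, and that step was a number 14 percentage points lower from compound 1 to compound 3 (beyond the scatter) in the other direction. The steps from compound 1 to compound 2 and from compound 2 to compound 3 were within the scatter. On this basis a modest rise in this assay is expected for compound 4, of about a number 9 percentage points higher from compound 3 to compound 4 (within the scatter), roughly back toward the number of compound 1.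

The estimate for compound 4 in this assay is 67%, with a range from 52% to 82%.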

Compound 4, a percentage reported as inhibition, in the whole organism at one dose (the size of the read-out at that dose, not a potency): 51%
For compound 4 the middle estimate is 16 percentage points above the measured one; the measured number lies below the stated range.
By their numbers in this assay, from the lowest: compounds 4, 3, 2 and 1 (each within the scatter of the next, the first and the last beyond it).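

In this assay the exchange of (ethylsulfonyl)methyl for 1-fluoroethyl, three bonds along the chain from a saturated ring carbon, gives a number 7 percentage points lower from compound 3 to compound 4 (within the scatter) and no order is drawn for that pair. The other two steps are firmer: a number 12 percentage points lower from compound 2 to compound 4 (beyond the scatter) and a number 21 percentage points lower from compound 1 to compound 4 (beyond the scatter) both place compound 4 apart, so a chain without the sulfonyl group does not by itself recover the number of compound 1, and compound 4 goes against tying the lower numbers to the sulfonyl group alone. Nothing available explains these steps.

Open, as far as these compounds go, is what a plain butyl chain, a hydroxyl group, an amine or a carboxylic acid at this place would give in this assay and thus whether the fluorine has any part in the number of compound 4.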